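The compounds below may be only part of what the source reports. "The series", "measured", "known", "first", "only" and "open" are said of these compounds alone.

Measured so far:
- compound 1 `Fc1ccc(C2=NN(c3nc(-c4ccccc4)cs3)C(c3cccs3)C2)cc1` — 2340 nM in a functional assay on MCF7 cells (Homo sapiens) for antiproliferative activity, read by MTT assay, with a stated time of 48 h; a lower number here means a stronger inhibitor, a higher number a weaker inhibitor
- compound 2 `Brc1ccc(C2=NN(c3nc(-c4ccc(Br)cc4)cs3)C(c3cccs3)C2)cc1` — 28300 nM in this assay

For the measured compounds named here, only two numbers exist. Compound 2 stands highest of them; compound 1 gives the lower number, and the gap between the two lies beyond the scatter. Going by the values given here, no pair of measured compounds differs in only one place, so no single-point step has been seen yet: compound 1 and compound 2 differ both on the aryl group attached to the pyrazoline carbon (fluoro against bromo) and on the aryl group attached to the thiazole (hydrogen against bromo).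

Compound 3 `Brc1ccc(C2=NN(c3nc(-c4ccccc4)cs3)C(c3cccs3)C2)cc1` removes one of those two differences. Relative to compound 2 the change is hydrogen in place of bromo on an aromatic carbon — hydrogen in place of bromo on an aromatic carbon, para to a large group; cut one bond further out, 4-bromophenyl becomes phenyl. Compound 3 thus shares the phenyl on the thiazole with compound 1 and the 4-bromophenyl on the pyrazoline with compound 2.

Among the compounds with values here, with no measured single-point step to lean on, the expectation rests on compound 2 sitting high and compound 1 low: compound 3 is expected to fall between them, nearer the lower figure. Compound 3 is estimated at 7000 nM (range 2500 nM to 25000 nM), a step of a 4.0-fold lower number from compound 2 to compound 3 (0.61 log units; beyond the scatter), expected to run downward and to exceed the scatter.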

Compound 3, half-maximal inhibitory concentration: 6790 nM
For compound 3 the middle estimate is 1.0-fold (0.01 log units) above the measured one; the range from low to high includes it.
By their numbers in this assay, from the lowest: compound 1; then compound 3; then compound 2.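

In this assay the series now has its first steps in one place: on the aryl group attached to the thiazole, 4-bromophenyl to phenyl gives a 4.2-fold lower number from compound 2 to compound 3 (0.62 log units; beyond the scatter) and shows that this bromo alone accounts for a change beyond the scatter. On the aryl group attached to the pyrazoline, bromo in place of fluoro gives a 2.9-fold higher number from compound 1 to compound 3 (0.46 log units; beyond the scatter) and shows that this second position also moves the number beyond the scatter, so the gap between compound 1 and compound 2 is not the work of one position alone. In these three compounds, each added bromo goes with a higher number and none goes against that pattern, but no measurement available here explains either step.

What the compounds shown leave open is whether the trend at each position depends on the group held at the other, since each step has been read against only one partner group. They also leave open how a methoxy group, an amine or a carboxylic acid would compare with hydrogen, fluoro and bromo on either aromatic ring.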